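Swapping the Ring of the Long-Lived Compound 3

The source may report more compounds than this note shows. Statements on the series, on what has been measured and on what is new or still open speak of the compounds shown alone.

Compound 3 `CC(C)C(c1noc(=O)[nH]1)c1ccc(-c2ccc3cccc(F)c3c2)[nH]c1=O` gives > 3 h in an ADME assay on microsomes from liver (Rattus norvegicus) for metabolic stability (on this read-out lower numbers stand for a shorter-lived compound and higher numbers for a longer-lived compound), which is a limit of the assay and not a true number. Compound 1 `CC(C)C(c1ccc(-c2ccc3cccc(F)c3c2)[nH]c1=O)N1CCCCC1=O` gives 0.102 h, and compound 2 `CC(C)C(c1cnc(N)s1)c1ccc(-c2ccc3cccc(F)c3c2)[nH]c1=O` gives 0.0983 h, so the data show a 1.0-fold lower number from compound 1 to compound 2 (0.02 log units; within the scatter). Compound 4 `CC(C)C(CC(N)=O)c1ccc(-c2ccc3cccc(F)c3c2)[nH]c1=O` keeps the shared core of compound 3 but changes one group: a group of 4 heavy atoms (2 carbon, 1 nitrogen, 1 oxygen; no ring) in place of a group of 6 heavy atoms (2 carbon, 2 nitrogen, 2 oxygen; one five-membered aromatic ring with 3 hetero atoms), on a saturated chain carbon bound to an aromatic carbon and a saturated chain carbon. Thus carbamoylmethyl, with no ring, enters on a saturated chain carbon bound to an aromatic carbon and a saturated chain carbon.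

Earlier changes at this same place bear directly on the new one. The data show an at least 29-fold higher number from compound 1 to compound 3 (1.46 log units; beyond the scatter), and they also show an at least 30-fold higher number from compound 2 to compound 3 (1.48 log units; beyond the scatter). Compound 4 loses the ring found only in compound 3, so it is expected to lose much of that gain and fall closer to compound 1 at 0.102 h. A large drop is expected, estimated as an at least 10-fold lower number from compound 3 to compound 4 (1.00 log units; beyond the scatter). For compound 4, the estimated half-life is 0.3 h, with an expected range from 0.08 h to 1.5 h.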

Compound 4, half-life: < 0.0667 h
Compound 4: no number, only a limit (the forecaster's own chance of this, stated with the estimate: 10%); at least 4.4-fold (0.65 log units) between middle value and limit.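

Compound 4 reads as a limit in this assay, not as a true number: the limit of < 0.0667 h in this assay, at which 1 of the 4 values shown sits. Even so, the data show an at least 44-fold lower number from compound 3 to compound 4 (1.65 log units; beyond the scatter), so carbamoylmethyl on this saturated chain carbon does not keep the long half-life seen with the five-membered aromatic ring of compound 3. The data also show an at least 1.4-fold lower number from compound 2 to compound 4 (0.16 log units; that floor lies within the scatter) and an at least 1.5-fold lower number from compound 1 to compound 4 (0.18 log units; that floor lies within the scatter), but both floors lie within the scatter, so no order can be read among these three short-lived compounds, and compound 3 alone stands apart.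

From the compounds shown here alone, it remains open which feature of the ring in compound 3 goes with the long half-life, the ring itself or its particular atoms. A carboxylic acid or a longer chain on this same carbon would give a further comparison with compound 3.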